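The compounds below may be only part of what the source reports. "The series", "measured", "known", "first", "only" and "open" are said of these compounds alone.

In a functional assay on SGC-7901 cells (Homo sapiens) for cytotoxicity, read by MTT assay, with a stated time of 38 h (on this read-out lower numbers stand for stronger inhibition and higher numbers for weaker inhibition), compound 1 `COc1cc(OC)c2c(=O)c(OCCCCN3CCCCC3)c(-c3cc(OC)c(OC)c(OC)c3)oc2c1` gives 6080 nM, compound 2 `COc1cc(OC)c2c(=O)c(OCC(=O)N/N=C/c3ccc[nH]3)c(-c3cc(OC)c(OC)c(OC)c3)oc2c1` gives 8730 nM and compound 3 `COc1cc(OC)c2c(=O)c(OCC(=O)N/N=C/c3ccco3)c(-c3cc(OC)c(OC)c(OC)c3)oc2c1` gives 5720 nM. All three lie within the scatter of one another, so compound 3 cannot be ranked against the other two. Compound 4 `COc1cc(OC)c2c(=O)c(OCC(=O)N/N=C/c3ccccn3)c(-c3cc(OC)c(OC)c(OC)c3)oc2c1` differs from compound 3 in one place: pyridin-2-yl in place of furan-2-yl on a carbon with a double bond to nitrogen. This puts pyridin-2-yl in place of furan-2-yl on a carbon with a double bond to nitrogen. Among the measured compounds shown here, the closest precedent is a 1.5-fold lower number from compound 2 to compound 3 (0.18 log units; within the scatter), a swap at that same place and within the scatter. The wider changes, a 1.4-fold higher number from compound 1 to compound 2 (0.16 log units; within the scatter) and a 1.1-fold lower number from compound 1 to compound 3 (0.03 log units; within the scatter), are also within it. No shift beyond the scatter is expected in this assay, and the estimated move is a 1.0-fold higher number from compound 3 to compound 4 (0.02 log units; within the scatter). Compound 4 is expected at 6000 nM, with an estimated range of 2500 nM to 14000 nM.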

Compound 4, half-maximal inhibitory concentration: 16200 nM
Compound 4: middle estimate off by 2.7-fold (0.43 log units), on the low side; measured number above the stated range.
By their numbers in this assay, from the lowest: compounds 3, 1, 2 and 4 (each within the scatter of the next, the first and the last beyond it).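

In this assay, among the compounds shown here, the group on a carbon with a double bond to nitrogen now shows an effect: a 2.8-fold higher number from compound 3 to compound 4 (0.45 log units; beyond the scatter) is the first step at this place to pass the scatter, if only modestly. By contrast, a 1.9-fold higher number from compound 2 to compound 4 (0.27 log units; within the scatter) stays within the scatter, so pyridin-2-yl separates from furan-2-yl but not from 1H-pyrrol-2-yl. The wider change, a 2.7-fold higher number from compound 1 to compound 4 (0.43 log units; beyond the scatter), also passes the scatter, unlike the steps from compound 1 to compound 2 or compound 3.

No evidence on hand bears on the reason for this step. On these data alone, whether a phenyl or aminophenyl group at this place would sit with furan-2-yl or with pyridin-2-yl remains open.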